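Nitro to Amino: From a Measured Amide Pair to an Ester

The source may hold more compounds than are shown below. What is called first, only, known or untested is meant among the compounds shown, and "the series" means these compounds.

Compound 1 `COc1ccc(NC(=O)c2cc(OC)c(OC)c(OC)c2)cc1[N+](=O)[O-]`: 38700 nM
Compound 2 `COc1ccc(NC(=O)c2cc(OC)c(OC)c(OC)c2)cc1N`: 4100 nM
Compound 3 `COc1ccc(OC(=O)c2cc(OC)c(OC)c(OC)c2)cc1[N+](=O)[O-]`: a limit only, > 100000 nM

In a functional assay on HeLa cells (Homo sapiens) for antiproliferative activity, read by MTT assay, with a stated time of 72 h (a lower number here means a stronger inhibitor, a higher number a weaker inhibitor), compound 1 gives 38700 nM. Compound 2 differs from it by amino in place of nitro on an aromatic carbon and gives 4100 nM in this assay, so that a 9.4-fold lower number from compound 1 to compound 2 (0.97 log units; beyond the scatter). For compound 3 the result in this assay is a limit of the assay and not a number, > 100000 nM; this is the limit of > 100000 nM in this assay, at which 1 of the 3 values shown sits. The difference between the core of compound 1 and the core of compound 3 is not broken down here.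

Compound 4 `COc1ccc(OC(=O)c2cc(OC)c(OC)c(OC)c2)cc1N` has not yet been measured. For the measured compounds named here, it differs from compound 3 by amino in place of nitro on an aromatic carbon, which is the same change, at the same kind of place, as the one from compound 1 to compound 2. For compound 4 the expected step is an at least 2.5-fold lower number from compound 3 to compound 4 (0.39 log units; beyond the scatter), and this expectation rests on the measured step of a 9.4-fold lower number from compound 1 to compound 2 (0.97 log units; beyond the scatter). Because compound 3 offers only a limit > 100000 nM, the starting point is uncertain, so the estimate is wide. Compound 4 is therefore expected to give about 40000 nM in this assay, most likely between 8000 nM and 200000 nM.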

Compound 4, half-maximal inhibitory concentration: > 100000 nM
Compound 4: no number, only a limit; the forecaster's own chance of this, stated with the estimate: 35%; middle value at least 2.5-fold (0.39 log units) away from the limit.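

In this assay, compound 3 and compound 4 each give only a limit of the assay and not a number, so the step between them cannot be read: the limit of > 100000 nM in this assay, at which 2 of the 4 values shown sit.

The compounds shown leave open whether amino in place of nitro lowers the number on the core of compound 3 as it does from compound 1 to compound 2.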